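Trimming a Side Chain on a Quinoline Amide Series

The source may report more compounds than this note shows. Statements on the series, on what has been measured and on what is new or still open speak of the compounds shown alone.

This study concerns a small set of compounds built on a shared core and tested in an ADME assay on A549 cells (Homo sapiens) for cytotoxicity, with a stated time of 72 h; a higher number here means a weaker inhibitor, a lower number a stronger inhibitor. Compound 1 `COc1cc(NC(C)CCCN2C(=O)[C@@H](C)N(C(=O)CN)C2(C)C)c2ncccc2c1` carries an aminoacetyl group on the ring nitrogen. In this assay compound 1 reaches only the limit of > 100000 nM. Compound 2 `COc1cc(N(C(C)=O)C(C)CCCN2C(=O)CN(C(C)=O)C2(C)C)c2ncccc2c1` has acetyl groups on both nitrogens. In this assay compound 2 likewise reaches only the limit of > 100000 nM. Among the compounds with values here, compound 3 `COc1cc(NC(C)CCCN2C(=O)CN(C(=O)[C@H](N)C(C)C)C2(C)C)c2ncccc2c1` is the one member with a measured number: in this assay compound 3 gives 5500 nM, so among the values shown it is the only compound that produces a readable result, the other two sitting at the limit of > 100000 nM in this assay, at which 2 of the 3 values shown sit.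

The next step removes most of that side chain. Compound 4 `COc1cc(NC(C)CCCN2C(=O)CN(C(C)=O)C2(C)C)c2ncccc2c1` differs from compound 3 as follows: methyl in place of 1-amino-2-methylpropyl on a carbonyl carbon. For compound 4 the expected direction in this assay is towards a weaker inhibitor, with the estimated step of a 7.3-fold higher number from compound 3 to compound 4 (0.86 log units; beyond the scatter) clearly beyond the scatter. Compound 4 is expected to give about 40000 nM, within a range of 8000 nM to 150000 nM, and a result at the limit would not be surprising.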

Compound 4, half-maximal inhibitory concentration: > 100000 nM
Compound 4 ended at the assay's limit (the forecaster's own chance of this, stated with the estimate: 50%); middle value at least 2.5-fold (0.39 log units) away from the limit.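

Within the data shown here, compound 3 was the only compound with a readable number, and this pair ties that reading to one place. On the carbonyl carbon whose other neighbour is the amide-type nitrogen in a ring, putting methyl in place of 1-amino-2-methylpropyl gives an at least 18-fold higher number from compound 3 to compound 4 (1.25 log units; beyond the scatter) in this assay, a large change from a single swap. The step between compound 2 and compound 4 cannot be read, as both values are limits, and the set now sits mostly at one end: the limit of > 100000 nM in this assay, at which 3 of the 4 values shown sit.

As far as these compounds go, what stays open is which part of the lost side chain matters, the amine or the branched carbons. A 2-methylpropyl group with no amine on this same carbonyl carbon would separate those two parts.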